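The compounds below may be only part of what the source reports. "The series", "measured", "known", "first", "only" and "open" are said of these compounds alone.

Compound 3 `COc1ccc(CNC(=O)/C=C/c2coc3cc(OC)ccc3c2=O)cc1` belongs to a small set of three measured analogues built on one shared core. In a functional assay on L02 cells (Homo sapiens) for inhibition, read by MTT assay, with a stated time of 48 h (a lower number here means a stronger inhibitor, a higher number a weaker inhibitor), compound 3 gives only the assay limit > 200000 nM. Compound 1 `COc1ccc2c(=O)c(/C=C/C(=O)Nc3ccccc3)coc2c1` also stops at the limit, > 200000 nM. Compound 2 `COc1ccc2c(=O)c(/C=C/C(=O)NCc3cccc(F)c3)coc2c1` likewise reaches only the limit, > 200000 nM. The whole set is covered by the limit of > 200000 nM in this assay, at which 3 of the 3 values shown sit, so the steps a step that the two limits leave unreadable from compound 1 to compound 2, a step that the two limits leave unreadable from compound 1 to compound 3 and a step that the two limits leave unreadable from compound 2 to compound 3 cannot be read. Compound 4 `COc1ccc2c(=O)c(/C=C/C(=O)Nc3ccc(F)cc3)coc2c1` differs from compound 3 by 4-fluorophenyl in place of 4-methoxybenzyl on an amide-type nitrogen. Within the data shown here, no measured step shows how such a change moves this assay; the swaps among compounds 1, 2 and 3 bear on it only by showing that no variation on the amide-type nitrogen has yet produced a number. Compound 4 is therefore expected to remain at the limit, the estimated step that the limit leaves unreadable from compound 3 to compound 4 being none readable. For compound 4 the estimate is 300000 nM, within a range of 100000 nM to 1000000 nM.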

Compound 4, half-maximal inhibitory concentration: > 200000 nM
Compound 4: a limit, no number (the forecaster's own chance of this, stated with the estimate: 90%); the middle value lies beyond the limit too.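

Compound 4 also gives only a limit in this assay, > 200000 nM. Its steps to compound 1, compound 2 and compound 3 therefore cannot be read: the limit of > 200000 nM in this assay, at which 4 of the 4 values shown sit.

The compounds shown leave open whether any group on the amide-type nitrogen yields an actual number in this assay.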